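The compounds below may be only part of what the source reports. "The series", "measured", "known", "first", "only" and "open" are said of these compounds alone.

The three measured compounds share one core and differ only in a single group on the aromatic ring. Compound 1 `CNc1nc(NC2(C#N)CCCCC2)nc(-n2ccnc2)n1` carries a 1H-imidazol-1-yl group there, and in an ADME assay on microsomes from liver (Rattus norvegicus) for metabolic stability (on this read-out higher numbers stand for fast clearance and lower numbers for slow clearance), compound 1 gives 52 mL/min/kg. Compound 2 `CNc1nc(NC2(C#N)CCCCC2)nc(OC)n1` carries a methoxy group instead, and compound 2 gives 196 mL/min/kg. Compound 3 `CNc1nc(NC2(C#N)CCCCC2)nc(C2CC2)n1` carries a cyclopropyl group, and compound 3 gives 276 mL/min/kg, the highest of the three numbers; its gap to compound 2 lies within the scatter, whereas a 5.3-fold higher number from compound 1 to compound 3 (0.72 log units; beyond the scatter).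

Compound 4 `CNc1nc(NC2(C#N)CCCCC2)nc(N(C)C)n1` differs from compound 3 in one place: dimethylamino in place of cyclopropyl on an aromatic carbon. Among the compounds with values here, two measured steps bear on this change. The first, a 5.3-fold higher number from compound 1 to compound 3 (0.72 log units; beyond the scatter), shows that removing the ring group in favour of cyclopropyl raised clearance clearly. The second, a 1.4-fold higher number from compound 2 to compound 3 (0.15 log units; within the scatter), shows that exchanging methoxy for cyclopropyl changed little. Dimethylamino, like methoxy, brings one hydrogen-bond acceptor and no ring, so it seems closer to compound 2 than to compound 1. The expected step is therefore a 1.6-fold lower number from compound 3 to compound 4 (0.21 log units; within the scatter), a mild move toward slower clearance, though it could well fall within the scatter. Compound 4 is estimated to give 170 mL/min/kg in this assay, with a likely range from 80 mL/min/kg to 330 mL/min/kg.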

Compound 4, clearance: 276 mL/min/kg
Compound 4: middle estimate off by 1.6-fold (0.21 log units), on the low side; measured number inside the range.
By their numbers in this assay, from the lowest: compound 1; then compounds 2, 3 and 4 (each within the scatter of the next).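

In this assay, dimethylamino at this position, on an aromatic carbon between two ring nitrogen atoms, reads the same as cyclopropyl, with no change at the digits printed from compound 3 to compound 4 (within the scatter) for that exchange, and it also matches methoxy, with a 1.4-fold higher number from compound 2 to compound 4 (0.15 log units; within the scatter) in that comparison. Cyclopropyl brings a small carbon ring and no hydrogen-bond acceptor, while dimethylamino brings no ring and one acceptor, yet this difference in make-up leaves no readable mark on clearance, so compounds 2, 3 and 4 now form a level group. Within the data shown here, compound 1 remains the only one apart from that group, as the exchange of 1H-imidazol-1-yl for dimethylamino gives a 5.3-fold higher number from compound 1 to compound 4 (0.72 log units; beyond the scatter) and so confirms the gap with a third group, but no measurement here explains that gap.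

As far as these compounds go, with a single compound at the slower-clearing end, it remains open whether other rings attached through nitrogen, such as pyrazol-1-yl or morpholine, would read like compound 1 or like the level group. From the compounds shown here alone, it is also open how a primary amine, a carboxylic acid or a longer alkyl chain at this position would read.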